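Amino for chloro across two aryl alkyne cores

A few compounds are considered here, and "the series" means these few. Any claim that something is new, unique, unknown or untested is made for them only; others in the source may bear on it.

Compound 1 `Fc1cccc(F)c1C#Cc1ccc2c(Cl)ccnc2c1` and compound 2 `Nc1ccnc2cc(C#Cc3c(F)cccc3F)ccc12` share one core; compound 3 `Fc1cccc(F)c1C#Cc1cnc(Cl)c2ccccc12` has the same atoms joined differently, and the difference between the two cores is not broken down here. In a functional assay on LS174T cells (Homo sapiens) for inhibition, with a stated time of 4 days, tested at 10 uM (a higher number here means a stronger effect of the compound at the concentration tested, a lower number a weaker effect), compound 1 gives 70.8%, compound 2 gives 97.7% and compound 3 gives 94%. The change from compound 1 to compound 2 is amino in place of chloro on an aromatic carbon and yields a number 26.9 percentage points higher from compound 1 to compound 2 (beyond the scatter). Compound 3 and compound 2 lie within the scatter of each other, while compound 3 stands beyond the scatter from compound 1.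

Compound 4 `Nc1ncc(C#Cc2c(F)cccc2F)c2ccccc12` is not yet measured. It differs from compound 3 by amino in place of chloro on an aromatic carbon. This is the same kind of change as that from compound 1 to compound 2, but the place differs: in compound 2 the amino sits opposite the ring nitrogen, whereas in compound 4 it sits next to the ring nitrogen and para to a large group. The step from compound 3 to compound 4 is expected to be a number 3 percentage points higher from compound 3 to compound 4 (within the scatter), smaller than the earlier one. That expectation rests on compound 3 already giving 94%, which leaves the read-out little room upward. Compound 4 is estimated at 97%, between 89% and 100%.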

Compound 4, a percentage reported as inhibition, at one concentration (the size of the read-out at that concentration, not a potency): 93.1%
Compound 4: middle estimate off by 3.9 percentage points, on the high side, and the stated range covers the measured number.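

In this assay, amino in place of chloro on the second core gives a number 0.9 percentage points lower from compound 3 to compound 4 (within the scatter), so the gain seen on the other core does not carry over in size, and the two steps differ: the same change on two cores in this assay, a number 26.9 percentage points higher (beyond the scatter) from compound 1 to compound 2 and a number 0.9 percentage points lower (within the scatter) from compound 3 to compound 4, 27.8 percentage points apart, beyond the scatter of two such steps. For these two pairs, the effect of this change therefore depends on the core or on where the amino sits, and the data do not separate those two differences. Nor do they show what lies behind the gap, or whether compound 3 and compound 4 would remain level at another concentration: each number is the size of the read-out at one concentration only.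

The compounds shown leave open how other groups would behave in place of the chloro on either core, for example a methylamino, a hydroxyl or a nitrile. They also leave open whether a longer chain on the amino nitrogen would give the same contrast between the two cores.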